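This account rests on a few compounds, and the source may have more. Where it says the series, first, only, none or still open, it means among the compounds named here.

Measured so far:
compound 1 `CNC(=O)c1ccc(Oc2cccc(NC(=S)Nc3ccc(Cl)cc3)c2)nc1`; in a functional assay on PC-3 cells (Homo sapiens) for antiproliferative activity, read by MTT assay (a higher number here means a weaker inhibitor, a lower number a stronger inhibitor), compound 1 gives 28400 nM
compound 2 `CNC(=O)c1ccc(Oc2cccc(NC(=S)Nc3cccc(C(F)(F)F)c3)c2)nc1`; in this assay compound 2 gives 15400 nM

Of these two numbers compound 2 has the smaller one, but the step of a 1.8-fold lower number from compound 1 to compound 2 (0.27 log units; within the scatter) is within the scatter, so no real difference between the two is shown. Compound 3 `CNC(=O)c1ccc(Oc2cccc(NC(=S)Nc3ccc(Cl)c(C(F)(F)F)c3)c2)nc1` differs from compound 2 by chloro in place of hydrogen on an aromatic carbon. Among the compounds with values here, the only measured step, a 1.8-fold lower number from compound 1 to compound 2 (0.27 log units; within the scatter), exchanges one substituted phenyl for another and says little about adding a chloro group; no step beyond the scatter is expected in this assay. Compound 3 is therefore estimated at 12000 nM (range 5000 nM to 30000 nM), an expected step of a 1.3-fold lower number from compound 2 to compound 3 (0.11 log units; within the scatter).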

Compound 3, half-maximal inhibitory concentration: 1980 nM
Beside the measured number, compound 3's estimate is 6.1-fold (0.78 log units) above it; the whole stated range lies above it.
By their numbers in this assay, from the lowest: compound 3; then compounds 2 and 1 (each within the scatter of the next).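

In this assay chloro in place of hydrogen, ortho to a trifluoromethyl group and para to a large group, gives a 7.8-fold lower number from compound 2 to compound 3 (0.89 log units; beyond the scatter) and so a step beyond the scatter, which the earlier pair did not show. Trifluoromethyl in place of hydrogen gives a 14-fold lower number from compound 1 to compound 3 (1.16 log units; beyond the scatter) in the same series, so the two groups together on one ring stand apart from either compound carrying only one of them. Nothing available bears on the cause of these steps.

On these data alone, whether bromo, methyl or an amine on that carbon would match chloro remains open. So does the effect of a carbonyl in place of the thiocarbonyl in compound 3.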